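Halogen series on the shared core: expected value for compound 4

This account rests on a few compounds, and the source may have more. Where it says the series, first, only, none or still open, it means among the compounds named here.

Going by the values given here, compound 3 `Cc1nn(-c2ccccc2F)c2c1C(c1ccc(Oc3ccccc3)cc1)SC(C)C(=O)N2` gives 3900 nM in an assay on isolated protein for agonist activity at Bile acid receptor (Homo sapiens), read by AlphaScreen, with a stated time of 30 min (on this read-out lower numbers stand for an effect already at smaller amounts and higher numbers for an effect only at larger amounts of compound), the highest of the three numbers measured so far; compound 2 `Cc1nn(-c2ccccc2Cl)c2c1C(c1ccc(Oc3ccccc3)cc1)SC(C)C(=O)N2` gives 2700 nM, within the scatter of compound 3, and compound 1 `Cc1nn(-c2ccccc2I)c2c1C(c1ccc(Oc3ccccc3)cc1)SC(C)C(=O)N2` gives 1300 nM, the lowest. Compound 4 `Cc1nn(-c2ccccc2Br)c2c1C(c1ccc(Oc3ccccc3)cc1)SC(C)C(=O)N2` differs from compound 3 by bromo in place of fluoro on an aromatic carbon. The measured steps that bear on this are a 3.0-fold higher number from compound 1 to compound 3 (0.48 log units; beyond the scatter), a 2.1-fold higher number from compound 1 to compound 2 (0.32 log units; beyond the scatter) and a 1.4-fold higher number from compound 2 to compound 3 (0.16 log units; within the scatter): across these three compounds the number falls as the halogen goes from fluoro through chloro to iodo, and none of them goes against that. Bromo stands between chloro and iodo in that series, so a lower number is expected for compound 4, with the step of a 2.2-fold lower number from compound 3 to compound 4 (0.34 log units; beyond the scatter) expected to reach beyond the scatter. The estimate for compound 4 is 1800 nM, with a range from 900 nM to 3600 nM.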

Compound 4, half-maximal effective concentration: 1800 nM
Compound 4: the middle estimate sits on the measured number at the digits printed; the range from low to high includes it.
By their numbers in this assay, from the lowest: compounds 1, 4, 2 and 3 (each within the scatter of the next, the first and the last beyond it).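

In this assay the change from 2-fluorophenyl to 2-bromophenyl gives a 2.2-fold lower number from compound 3 to compound 4 (0.34 log units; beyond the scatter), so bromo and fluoro can be told apart at this place on the aromatic ring. Bromo cannot be told apart from its two other halogen neighbours: a 1.5-fold lower number from compound 2 to compound 4 (0.18 log units; within the scatter) and a 1.4-fold higher number from compound 1 to compound 4 (0.14 log units; within the scatter) both lie within the scatter, so chloro, bromo and iodo are not ranked by these steps. Nothing at hand accounts for the dependence on the halogen. On these data alone, whether a methyl, a methoxy or an amine at this place would fall within the halogen range remains open.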